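The source may report more compounds than this note shows. Statements on the series, on what has been measured and on what is new or still open speak of the compounds shown alone.

Working notes on the series. Of the compounds shown here, three on a shared core have been measured so far. Compound 1 `Cc1nc2c(Br)c(Br)c(Br)c(Br)c2n1CC#N` gives in a functional assay on MCF7 cells (Homo sapiens) for cytotoxicity, read by MTT assay, with a stated time of 24 h, tested at 20 uM (a higher number here means a weaker effect of the compound at the concentration tested, a lower number a stronger effect), a value of 36% for compound 1. Going by the values given here, compound 2 `Cc1nc2c(Br)c(Br)c(Br)c(Br)c2n1CCCCC#N` carries a longer chain on the aromatic nitrogen, and compound 2 gives 110%; the step of a number 74 percentage points higher from compound 1 to compound 2 (beyond the scatter) is the only single-place change among the measured compounds. Compound 3 `N#CCCn1cnc2c(Br)c(Br)c(Br)c(Br)c21` gives 72% for compound 3, which stands second highest of the three numbers, beyond the scatter from both compound 1 below it and compound 2 above it.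

The next compound, compound 4 `N#CCCCn1cnc2c(Br)c(Br)c(Br)c(Br)c21`, differs from compound 3 in one place: cyanomethyl in place of cyano on a saturated chain carbon, two bonds along the chain from an aromatic nitrogen. Read one bond further out, the same difference is 2-cyanoethyl to 3-cyanopropyl, a lengthening of the chain by one carbon. The step of a number 74 percentage points higher from compound 1 to compound 2 (beyond the scatter) bears on this, as it lengthens the same kind of chain on the same aromatic nitrogen, there by two carbons, and raised the number strongly. A smaller rise is therefore expected here, in the direction of a weaker effect in this assay.

Compound 4 is thus estimated at 95%, within 72% to 118%. The expected step is a number 23 percentage points higher from compound 3 to compound 4 (beyond the scatter).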

Compound 4, a percentage reported as activity, at one concentration (the size of the read-out at that concentration, not a potency): 70%
The estimate for compound 4 lay 25 percentage points above the measured number; measured number below the stated range.
By their numbers in this assay, from the lowest: compound 1; then compounds 4 and 3 (each within the scatter of the next); then compound 2.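

Lengthening 2-cyanoethyl to 3-cyanopropyl on the aromatic nitrogen gives a number 2 percentage points lower from compound 3 to compound 4 (within the scatter) in this assay and so no readable change at this place. Chain lengthening on this nitrogen therefore does not act alike across the series: the step of a number 74 percentage points higher from compound 1 to compound 2 (beyond the scatter) stands as a large rise for a lengthening by two carbons on the core of compound 1, whereas the lengthening by one carbon on the core of compound 3 does not separate from the scatter. Nothing measured in the series accounts for the contrast between these two steps.

The compounds shown leave open whether this contrast follows the size of the lengthening or the core that carries the chain. Also open, going by these compounds, is how the read-out at this place responds to a longer chain on the core of compound 3, or to a carboxylic acid or an amine in place of the nitrile.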